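Amide aryl variation on a bis-indole nitrile core

The compounds below may be only part of what the source reports. "The series", "measured", "known", "first", "only" and "open" are said of these compounds alone.

Measured so far in a functional assay on HCT-116 cells (Homo sapiens) for cytotoxicity, read by MTT assay, with a stated time of 72 h; on this read-out higher numbers stand for weaker inhibition and lower numbers for stronger inhibition:
compound 1, `CN1[C@@H]2c3[nH]c4ccccc4c3C[C@H]1[C@H](C#N)N1[C@@H](CNC(=O)c3cccc(C(F)(F)F)c3)c3[nH]c4ccccc4c3C[C@@H]21`, gives 630 nM
compound 2, `CN1[C@@H]2c3[nH]c4ccccc4c3C[C@H]1[C@H](C#N)N1[C@@H](CNC(=O)c3ccc(Cl)cc3)c3[nH]c4ccccc4c3C[C@@H]21`, gives 630 nM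
compound 3, `CN1[C@@H]2c3[nH]c4ccccc4c3C[C@H]1[C@H](C#N)N1[C@@H](CNC(=O)c3ccc(F)cc3)c3[nH]c4ccccc4c3C[C@@H]21`, gives 140 nM

Compound 3 stands at the lowest number of the three. From compound 1 to compound 2 the change is no change at the digits printed from compound 1 to compound 2 (within the scatter), whereas a 4.5-fold lower number from compound 1 to compound 3 (0.65 log units; beyond the scatter) and a 4.5-fold lower number from compound 2 to compound 3 (0.65 log units; beyond the scatter) both mark a modest step beyond the scatter, so compound 3 is the strongest inhibitor in this small set.

Compound 4, `CN1[C@@H]2c3[nH]c4ccccc4c3C[C@H]1[C@H](C#N)N1[C@@H](CNC(=O)c3cccc4c3CCCC4)c3[nH]c4ccccc4c3C[C@@H]21`, differs from compound 3 in one place: 1,2,3,4-tetrahydronaphthalen-5-yl in place of 4-fluorophenyl on a carbonyl carbon. Among the compounds with values here, no measured step introduces a six-membered non-aromatic ring on the amide aryl group, so the comparison is indirect. What the data do show is that the two alternatives to 4-fluorophenyl, 3-(trifluoromethyl)phenyl in compound 1 and 4-chlorophenyl in compound 2, both sit at a higher number than compound 3 by the steps of a 4.5-fold lower number from compound 1 to compound 3 (0.65 log units; beyond the scatter) and a 4.5-fold lower number from compound 2 to compound 3 (0.65 log units; beyond the scatter) read in reverse. A change to 1,2,3,4-tetrahydronaphthalen-5-yl is therefore expected to move compound 4 back toward the higher numbers, with a step estimated at a 3.2-fold higher number from compound 3 to compound 4 (0.51 log units; beyond the scatter) in this assay. For compound 4 the expected value is 450 nM, with a range from 150 nM to 1400 nM.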

Compound 4, half-maximal inhibitory concentration: 4210 nM
For compound 4 the middle estimate is 9.4-fold (0.97 log units) below the measured one; measured number outside the range, above it.
By their numbers in this assay, from the lowest: compound 3; then compounds 1 and 2 (each within the scatter of the next); then compound 4.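

In this assay the aryl group on the carbonyl carbon proves less forgiving than compounds 1, 2 and 3 alone suggested: 1,2,3,4-tetrahydronaphthalen-5-yl in place of 4-fluorophenyl gives the largest step in the series (a 30-fold higher number from compound 3 to compound 4 (1.48 log units; beyond the scatter)), and compound 4 now carries the highest number of the four. The same exchange also lies beyond the scatter against the other two aryl groups (a 6.7-fold higher number from compound 2 to compound 4 (0.82 log units; beyond the scatter)) and (a 6.7-fold higher number from compound 1 to compound 4 (0.82 log units; beyond the scatter)), so the loss is not confined to the comparison with 4-fluorophenyl, and this position spreads the series over a wider range than the three halogen-bearing amides showed. No measured reason for these steps is available.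

Compound 4 differs from the others both in carrying a six-membered non-aromatic ring and in having no halogen on the aryl group, and the compounds shown do not separate these two changes. On these data alone, a plain phenyl, a naphthalen-1-yl or a cyclohexyl group on the carbonyl carbon would tell them apart, and the effect of an amine or a carboxylic acid on the aryl ring remains open.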